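Compound 3: fluoro in place of methyl

The source may hold more compounds than are shown below. What is called first, only, known or untested is meant among the compounds shown, and "the series" means these compounds.

Values in a functional assay on A549 cells (Homo sapiens) for antiproliferative activity, read by MTT assay, with a stated time of 24 h; a higher number here means a weaker inhibitor, a lower number a stronger inhibitor:
compound 1 `Cc1ccc(-c2nn(-c3ccccc3)cc2-c2nc3ccccc3[nH]2)cc1`: 4010 nM
compound 2 `Cc1ccc(-c2nn(-c3ccccc3)cc2-c2nc3ccccc3n2S(=O)(=O)c2cc(C)ccc2C)cc1`: 270 nM

Within the data shown here, compound 2 gives the lower of the two numbers, with 270 nM on record in this assay so far. Among the measured compounds shown here, the only measured step is a 15-fold lower number from compound 1 to compound 2 (1.17 log units; beyond the scatter) and it is large, beyond the scatter. That step concerns the (2,5-dimethylphenyl)sulfonyl group on an aromatic nitrogen, which compound 3 `Cc1ccc(C)c(S(=O)(=O)n2c(-c3cn(-c4ccccc4)nc3-c3ccc(F)cc3)nc3ccccc32)c1` retains.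

The change now under test lies elsewhere: fluoro in place of methyl on an aromatic carbon with fluoro in place of methyl on an aromatic carbon, para to a large group, so that 4-methylphenyl becomes 4-fluorophenyl. For the measured compounds named here, no measured step covers this position, so the data give no direction for the change and no guide to its size. The starting point is therefore compound 2 at 270 nM and no step beyond the scatter is expected in this assay here.

The expected result is a 1.0-fold lower number from compound 2 to compound 3 (0.02 log units; within the scatter) as a working estimate, with the direction left open. Compound 3 is estimated at 260 nM with an expected range from 90 nM to 750 nM in this series.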

Compound 3, half-maximal inhibitory concentration: 200 nM
The estimate for compound 3 lay 1.3-fold (0.11 log units) above the measured number, within the range that was stated.
By their numbers in this assay, from the lowest: compounds 3 and 2 (each within the scatter of the next); then compound 1.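

In this assay, among these compounds, the change from 4-methylphenyl to 4-fluorophenyl gives a 1.4-fold lower number from compound 2 to compound 3 (0.13 log units; within the scatter), which is the first measured step at this position, on an aromatic carbon para to a large group. Within this one pair, methyl and fluoro cannot be told apart in this read-out, so the position shows no sensitivity to this particular exchange, although a single step of this kind sets no general rule for the position and holds only with the (2,5-dimethylphenyl)sulfonyl group in place on the aromatic nitrogen. No accompanying data bear on why the two compounds read alike.

Methyl and fluoro are both single-atom substituents, so the series does not yet show how this position responds to a larger or differently built group such as methoxy, an amine, a carboxylic acid or a longer chain. Going by these compounds, it also remains open whether the same exchange would read alike in the core of compound 1, which has hydrogen on the aromatic nitrogen in place of the sulfonyl group.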